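Compound 3 to compound 4: chloro in place of methyl

The compounds below may be only part of what the source reports. "The series", "measured", "known", "first", "only" and "open" are said of these compounds alone.

Compound 1 `CN1CCN(c2ccc(Nc3ncc4nc(Nc5cccc([N+](=O)[O-])c5)n(C5CCCC5)c4n3)cc2)CC1`: < 0.01 nM (a limit)
Compound 2 `C#Cc1cccc(Nc2nc3cnc(Nc4ccc(N5CCN(C)CC5)cc4)nc3n2C2CCCC2)c1`: < 0.01 nM (a limit)
Compound 3 `Cc1cccc(Nc2nc3cnc(Nc4ccc(N5CCN(C)CC5)cc4)nc3n2C2CCCC2)c1`: < 0.01 nM (a limit)

In a functional assay on HCC827 cells (Homo sapiens) for cytotoxicity, read by MTT assay, with a stated time of 72 h (a lower number here means a stronger inhibitor, a higher number a weaker inhibitor), compound 3 gives < 0.01 nM, which is a limit and not a number. Compound 4 `CN1CCN(c2ccc(Nc3ncc4nc(Nc5cccc(Cl)c5)n(C5CCCC5)c4n3)cc2)CC1` differs from it by chloro in place of methyl on an aromatic carbon. Three measured swaps at this aromatic carbon bear on the change: a step that the two limits leave unreadable from compound 1 to compound 2, a step that the two limits leave unreadable from compound 1 to compound 3 and a step that the two limits leave unreadable from compound 2 to compound 3. Compound 3 shares the limit of < 0.01 nM in this assay, at which 3 of the 3 values shown sit, with compound 1 and compound 2, so no size can be read from them. No step beyond the scatter is therefore expected in this assay, and no direction is expected. The expected change is a number no lower from compound 3 to compound 4 (the limit leaves the size open). For compound 4 the estimate is 0.01 nM. The expected range for compound 4 runs from 0.003 nM to 0.1 nM.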

Compound 4, half-maximal inhibitory concentration: < 0.01 nM
Compound 4 gave a limit, no number; the forecaster's own chance of this, stated with the estimate: 60%; the middle value sits exactly at the limit.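

Compound 4 joins compound 1, compound 2 and compound 3 as a limit and not a number in this assay, so no new step can be read: the limit of < 0.01 nM in this assay, at which 4 of the 4 values shown sit.

The compounds shown leave open whether nitro, ethynyl, methyl and chloro on this aromatic carbon differ at all in this assay.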